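The source may hold more compounds than are shown below. What is called first, only, known or untested is meant among the compounds shown, and "the series" means these compounds.

Measured so far in a functional assay on CHO cells with adenosine receptor A1 (Homo sapiens) as the target, read by cAMP accumulation and immunoassay, with a stated time of 6 min, tested at 0.1 uM; a higher number here means a weaker effect of the compound at the concentration tested, a lower number a stronger effect:
Compound 1, `Nc1scc(CN2CCN(c3cc(Cl)cc(Cl)c3)CC2)c1C(=O)c1ccc(Cl)cc1`, gives -22%.
Compound 2, `Nc1scc(CN2CCN(c3ccc(F)cc3Cl)CC2)c1C(=O)c1ccc(Cl)cc1`, gives -6.2%.

Compound 2 stands highest of the two numbers in this assay; compound 1 lies a number 15.8 percentage points higher from compound 1 to compound 2 (beyond the scatter), so the two are told apart beyond the scatter, both values sitting close to no effect. The unmeasured compound 3, `Nc1scc(CN2CCN(c3cc(F)ccc3F)CC2)c1C(=O)c1ccc(Cl)cc1`, differs from compound 2 only in the group on the ring nitrogen: 2,5-difluorophenyl in place of 2-chloro-4-fluorophenyl on an amine nitrogen in a ring. Among the compounds with values here, the one measured step that bears on this, a number 15.8 percentage points higher from compound 1 to compound 2 (beyond the scatter), also swapped the pattern of halogens on that same phenyl ring and moved the read-out by a modest amount. A second swap of that kind is therefore expected to shift this assay by a similarly modest amount at most, in either direction, with a fair chance of no change beyond the scatter. Compound 3 is estimated at -10%, in the range -30% to 10%, which means an expected step of a number 3.8 percentage points lower from compound 2 to compound 3 (within the scatter).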

Compound 3, a percentage reported as activity, at one concentration (the size of the read-out at that concentration, not a potency): -13%
Compound 3: middle estimate off by 3 percentage points, on the high side; low and high end bracket the measured number.
By their numbers in this assay, from the lowest: compounds 1, 3 and 2 (each within the scatter of the next, the first and the last beyond it).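

In this assay the swap of 2-chloro-4-fluorophenyl for 2,5-difluorophenyl on the amine nitrogen in the ring gives a number 6.8 percentage points lower from compound 2 to compound 3 (within the scatter) and so shows no real change, even with one chlorine gone and a second fluorine in its place. Going from 3,5-dichlorophenyl to the same 2,5-difluorophenyl gives a number 9 percentage points higher from compound 1 to compound 3 (within the scatter) and so compound 3 cannot be told apart from either of the other two, although compound 1 and compound 2 can be told apart from each other. Across these three compounds, changing the halogens on this phenyl ring moves the read-out little, and only the pair of compound 1 and compound 2 goes against a flat picture.

Nothing available explains these small differences. From the compounds shown here alone, it stays open whether a phenyl ring without halogens, or one carrying a methoxy group or an amine, would shift the read-out further.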